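The source may hold more compounds than are shown below. What is called first, only, known or untested is meant among the compounds shown, and "the series" means these compounds.

Measured so far in a functional assay on A-431 cells (Homo sapiens) for cytotoxicity; a lower number here means that less compound is needed, a higher number that more compound is needed for the effect

- Compound 1 `COC1=C(C)C(=O)/C(=C(O)/C=C/c2ccc(OC)cc2)C(=O)C1(C)C` gives 9.2 ug/mL
- Compound 2 `COC1=C(C)C(=O)/C(=C(O)/C=C/c2ccc(C)cc2)C(=O)C1(C)C` gives 5.1 ug/mL
- Compound 3 `COC1=C(C)C(=O)/C(=C(O)/C=C/c2cccc3ccccc23)C(=O)C1(C)C` gives 4.1 ug/mL

These three compounds share one core and differ only in an aromatic group. The numbers do not separate compound 2 from compound 1 or from compound 3, as both gaps lie within the scatter of repeated measurements.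

Compound 4 `COC1=C(C)C(=O)/C(=C(O)/C=C/c2ccco2)C(=O)C1(C)C` has not yet been measured. It carries furan-2-yl in place of 4-methylphenyl on a double-bonded chain carbon bound to a double-bonded chain carbon, and the counted difference from compound 2 is furan-2-yl in place of 4-methylphenyl on a double-bonded chain carbon bound to a double-bonded chain carbon here.

For the measured compounds named here, one measured step bears on this change, and only indirectly. It is a 1.8-fold lower number from compound 1 to compound 2 (0.26 log units; within the scatter) and it comes from methyl in place of methoxy on an aromatic carbon. Compound 3 has yet another aromatic group, and its 4.1 ug/mL stays within the scatter of compound 2. Going by the values given here, no measured compound carries furan-2-yl, so the size of this swap remains unknown, and replacing a whole group may matter more than the small change already seen.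

In this assay no change beyond the scatter is expected, and the estimated shift is a 1.2-fold higher number from compound 2 to compound 4 (0.07 log units; within the scatter) with no firm direction. The expected value for compound 4 is 6 ug/mL with an estimated range from 2.5 ug/mL to 14 ug/mL for now.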

Compound 4, concentration for half-maximal effect: 14.7 ug/mL
Compound 4: the middle estimate sits 2.5-fold (0.39 log units) below what was measured; the whole stated range lies below it.
By their numbers in this assay, from the lowest: compounds 3, 2, 1 and 4 (each within the scatter of the next, the first and the last beyond it).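

In this assay, for the compounds shown here, the group at this place on the chain now gives a step beyond the scatter: furan-2-yl in place of 4-methylphenyl gives a 2.9-fold higher number from compound 2 to compound 4 (0.46 log units; beyond the scatter), which shows that this position does respond to the group it carries, something the one earlier step, within the scatter, could not show. The size of the swap depends on the group that leaves, as furan-2-yl in place of 4-methoxyphenyl gives only a 1.6-fold higher number from compound 1 to compound 4 (0.20 log units; within the scatter), so compound 4 is set apart from compound 2 but not from compound 1. No measurement at hand gives a reason for the larger step.

All the groups shown at this place are aromatic rings, so it remains open how the assay would respond to an amine, a carboxylic acid or a longer chain there. Going by these compounds, it is also open whether the higher number belongs to furan-2-yl alone or extends to other five-membered aromatic rings, such as thiophene, which has sulfur where furan has oxygen.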